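A few compounds are considered here, and "the series" means these few. Any claim that something is new, unique, unknown or untested is made for them only; others in the source may bear on it.

Compound 3, `O=C(O)CCC/C=C1\C[C@H]2C[C@@H](O)[C@H](/C=N/NC(=O)Nc3ccccc3)[C@H]2C1`, is tested in a functional assay on a cell-free system (plasma) for agonist activity at thromboxane A2 receptor (Homo sapiens) (on this read-out lower numbers stand for stronger inhibition and higher numbers for weaker inhibition), where compound 3 gives 1700 nM. Among the three compounds measured, this is the second highest number. The closest is compound 2, `O=C(O)CC/C=C1\C[C@H]2C[C@@H](O)[C@H](/C=N/NC(=O)Nc3cccc(Cl)c3)[C@H]2C1`, which in this assay gives 5200 nM, a higher number than compound 3 and beyond the scatter. The furthest is compound 1, `O=C(O)CC/C=C1/C[C@H]2C[C@@H](O)[C@H](/C=N/NC(=O)Nc3ccc([N+](=O)[O-])cc3)[C@H]2C1`, which in this assay gives 20 nM, a far lower number and well beyond the scatter. Compounds 1 and 2 differ from compound 3 in several places, so their numbers show only that the range of outcomes in this series is wide.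

Compound 4, `O=C(O)CCC/C=C1/C[C@H]2C[C@@H](O)[C@H](/C=N/NC(=O)Nc3ccccc3)[C@H]2C1`, is not yet measured. Compared with compound 3, (the two compounds have the same atoms and bonds and differ only in configuration as drawn: 1 of 6 stereo elements differ; a double bond is drawn E in compound 3 and Z in compound 4). For the measured compounds named here, no measured pair in this set differs in exactly this way, so the size of the step is uncertain. A change in the number beyond the scatter is expected, with the lower number the more likely direction. The expected step is a 3.4-fold lower number from compound 3 to compound 4 (0.53 log units; beyond the scatter). For compound 4 the estimate in this assay is 500 nM, with a range from 100 nM to 3000 nM.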

Compound 4, half-maximal inhibitory concentration: 100 nM
The estimate for compound 4 lay 5.0-fold (0.70 log units) above the measured number; low and high end bracket the measured number.
By their numbers in this assay, from the lowest: compound 1; then compound 4; then compound 3; then compound 2.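

In this assay, the step is a 17-fold lower number from compound 3 to compound 4 (1.23 log units; beyond the scatter), and it is large even though no atom enters or leaves. The earlier compounds shown here differed from one another in several places, so their wide range of numbers could not be tied to any single feature, whereas this pair ties a large change to the double bond alone, drawn E in compound 3 and Z in compound 4. The step can be assigned to that double bond because of one fact: the fact that compounds 3 and 4 differ only in the configuration as drawn.

Among the compounds shown, neither compound 1 nor compound 2 has a partner differing only at this double bond, so whether the step holds elsewhere in the series stays open. Also open, on these data alone, is how the number of compound 4 would respond to a tetrazole in place of the carboxylic acid.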